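The source may report more compounds than this note shows. Statements on the series, on what has been measured and on what is new or still open speak of the compounds shown alone.

Compound 1 `Cc1cc(NCc2ccccn2)n2ncc(-c3ccc(C#N)cc3)c2n1`: in a physicochemical assay for solubility, read by HPLC, using the shake flask method, measured as kinetic solubility, with a stated time of 2 h, at pH 7.4 (on this read-out lower numbers stand for lower solubility and higher numbers for higher solubility), compound 1 gives only a limit, < 5000 nM.
Compound 2 `Cc1cc(NCc2ccccn2)n2ncc(-c3c(C)cccc3C)c2n1`: in this assay compound 2 also gives only a limit, < 5000 nM.
Compound 3 `Cc1cc(NCc2ccccn2)n2ncc(-c3cc(F)c(F)c(F)c3)c2n1`: in this assay compound 3 again gives only a limit, < 5000 nM.

Compound 3 therefore stands where every measured compound in this series stands, at the limit of < 5000 nM in this assay, at which 3 of the 3 values shown sit, and no order among the three can be read from their numbers. The three comparisons that join them, a step that the two limits leave unreadable from compound 1 to compound 2, a step that the two limits leave unreadable from compound 1 to compound 3 and a step that the two limits leave unreadable from compound 2 to compound 3, all remain unreadable for the same reason: a limit on each side leaves the size of the change hidden.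

Compound 4 `Cc1cc(NCc2ccccn2)n2ncc(-c3ccco3)c2n1` is the next compound in this assay. Its difference from compound 3 is furan-2-yl in place of 3,4,5-trifluorophenyl on an aromatic carbon. Within the data shown here, because the measured steps a step that the two limits leave unreadable from compound 1 to compound 3 and a step that the two limits leave unreadable from compound 2 to compound 3 carry no readable size, they give no direction for the change from compound 3 to compound 4, and the expected step that the limit leaves unreadable from compound 3 to compound 4 rests only on the fact that every value so far sits at the same limit. Compound 4 is therefore expected to give about 4000 nM, within a range from 500 nM to 25000 nM, with a real chance that it too is reported only as a limit.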

Compound 4, solubility: 48800 nM
For compound 4 the middle estimate is 12-fold (1.09 log units) below the measured one; the measured number lies above the stated range.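

On this aromatic carbon, furan-2-yl in place of each larger aromatic group gives an at least 9.7-fold higher number from compound 3 to compound 4 (0.98 log units; beyond the scatter), an at least 9.7-fold higher number from compound 2 to compound 4 (0.98 log units; beyond the scatter) and an at least 9.7-fold higher number from compound 1 to compound 4 (0.98 log units; beyond the scatter) in this assay. All three steps lie beyond the usual scatter, so the group at this place on the shared core can move the read-out, which the earlier compounds alone could not show: the limit of < 5000 nM in this assay, at which 3 of the 4 values shown sit.

The steps among compound 1, compound 2 and compound 3 still cannot be read. The change from compound 3 to compound 4 swaps a six-membered aromatic ring of carbon only for a five-membered aromatic ring with 1 hetero atom, so ring size and the oxygen cannot be told apart here. From the compounds shown here alone, a sulfur-containing thiophen-2-yl ring or a pyridyl ring would bear on that question, and how an amine on this carbon would read remains open.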